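The compounds below may be only part of what the source reports. "The series", "measured", "known", "first", "only" and "open" are said of these compounds alone.

Measured so far in an ADME assay on HeLa cells (Homo sapiens) for cytotoxicity, read by MTT assay; on this read-out higher numbers stand for weaker inhibition and lower numbers for stronger inhibition:
- compound 1 `COc1ccc(C[C@H]2COC(=O)[C@@H]2Cc2ccc(OCC(=O)Nc3ccc(C)cc3)c(OC)c2)cc1OC` gives 228000 nM
- compound 2 `COc1ccc(C[C@H]2COC(=O)[C@@H]2Cc2ccc(OCc3cn(Cc4ccccc4Cl)nn3)c(OC)c2)cc1OC` gives 84500 nM
- compound 3 `COc1ccc(C[C@H]2COC(=O)[C@@H]2Cc2ccc(OCc3cn(-c4cccc(Cl)c4)nn3)c(OC)c2)cc1OC` gives 493000 nM

Compound 3 stands highest of the three numbers in this assay and compound 2 lowest. Compound 4 `COc1ccc(C[C@H]2COC(=O)[C@@H]2Cc2ccc(OCc3cn(-c4ccccc4)nn3)c(OC)c2)cc1OC` differs from compound 3 in one place: hydrogen in place of chloro on an aromatic carbon In words, this is hydrogen in place of chloro on an aromatic carbon, 3-chlorophenyl to phenyl.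

Going by the values given here, no measured step removes a chloro alone, so the evidence is indirect. The step of a 5.8-fold higher number from compound 2 to compound 3 (0.77 log units; beyond the scatter) accompanies 3-chlorophenyl in place of 2-chlorobenzyl on an aromatic nitrogen. The step of a 2.2-fold higher number from compound 1 to compound 3 (0.33 log units; beyond the scatter) accompanies a replacement of the whole (4-methylphenyl)carbamoyl group. Both are modest, and both involve more than the present change, so a smaller step is expected here. With compound 3 at 493000 nM as the top of the three numbers, a lower number is the likelier side. The expected step is a 1.5-fold lower number from compound 3 to compound 4 (0.17 log units; within the scatter) as a working estimate. For compound 4 the estimated value is 330000 nM (expected range 130000 nM to 700000 nM) on present data.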

Compound 4, half-maximal inhibitory concentration: 124000 nM
Compound 4: the middle estimate sits 2.7-fold (0.43 log units) above what was measured; measured number below the stated range.
By their numbers in this assay, from the lowest: compounds 2, 4 and 1 (each within the scatter of the next, the first and the last beyond it); then compound 3.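

In this assay, the chloro alone separates compound 3 from the others: a 4.0-fold lower number from compound 3 to compound 4 (0.60 log units; beyond the scatter), so the high number goes with this one chlorine on the phenyl ring and not with the triazole series as a whole. With the ring left as plain phenyl, the compound no longer stands apart, with a 1.5-fold higher number from compound 2 to compound 4 (0.17 log units; within the scatter) and a 1.8-fold lower number from compound 1 to compound 4 (0.26 log units; within the scatter), both within the scatter. Nothing measured on hand explains the effect of the chloro on this read-out.

From the compounds shown here alone, whether chloro acts the same way on another carbon of the ring stays open, as does the outcome for a fluoro, methoxy, amine or carboxylic acid at this place. Also open is what the chloro contributes in compound 2, since an unsubstituted benzyl group on the triazole nitrogen is not among the compounds shown.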